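From Pyridin-4-yl to 2-(4-Chlorophenyl)ethenyl: What to Expect

The compounds below may be only part of what the source reports. "The series", "measured", "known", "first", "only" and "open" are said of these compounds alone.

Three compounds have been measured in an assay on CHO cells for displacement of a labelled ligand from adenosine receptor A1 (Homo sapiens), read by scintillation counting, tested at 10 uM; a lower number here means less inhibition, a higher number more inhibition at the concentration tested (going by the name of the read-out):
compound 1 `Cc1csc(N)c1C(=O)c1ccc(Cl)cc1` gives 1%;
compound 2 `COc1ccc(-c2sc(N)c(C(=O)c3ccc(Cl)cc3)c2C)cc1` gives 1%;
compound 3 `CC(C)(C)Cc1c(-c2ccncc2)sc(N)c1C(=O)c1ccc(Cl)cc1` gives 1%.

Compound 3 stands level with compound 1 and compound 2 at the digits shown; its nearest neighbour is compound 1 and its furthest is compound 2, and neither gap exceeds the scatter. Compound 4 `CC(C)(C)Cc1c(/C=C/c2ccc(Cl)cc2)sc(N)c1C(=O)c1ccc(Cl)cc1` differs from compound 3 in one place: 2-(4-chlorophenyl)ethenyl in place of pyridin-4-yl on an aromatic carbon. For the measured compounds named here, the only measured step, no change at the digits printed from compound 1 to compound 2 (within the scatter), also places an aromatic group on an aromatic carbon of the shared core and showed nothing beyond the scatter; no measured step exchanges one such group for another. The step of a number 1 percentage points higher from compound 3 to compound 4 (within the scatter) is therefore expected to be none beyond the scatter. Compound 4 is accordingly estimated at 2%, within a range from 0% to 15%.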

Compound 4, a percentage reported as inhibition, at one concentration (the size of the read-out at that concentration, not a potency): 1%
Beside the measured number, compound 4's estimate is 1 percentage points above it, within the range that was stated.
By their numbers in this assay, from the lowest: compounds 1, 2, 3 and 4 (each within the scatter of the next).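

In this assay, exchanging one aromatic group for another on this carbon next to the ring sulfur gave no change at the digits printed from compound 3 to compound 4 (within the scatter). Even with the neopentyl group in place, neither pyridin-4-yl nor 2-(4-chlorophenyl)ethenyl, with its double bond outside the aromatic rings, separates the two compounds. No evidence is available that bears on this result.

The compounds shown leave open whether any group on this carbon can produce measurable inhibition at the concentration tested. An amine or a carboxylic acid here, or a longer chain in place of neopentyl, could address that question.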